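Methyl on the phenol: one step within the scatter

The compounds below may be only part of what the source reports. "The series", "measured", "known", "first", "only" and "open" are said of these compounds alone.

Three compounds that share one core have been examined in a functional assay on the whole organism (strain albino) with Mus musculus as the target, with a stated time of 4 h; on this read-out lower numbers stand for an effect already at smaller amounts and higher numbers for an effect only at larger amounts of compound. Compound 1 `COc1ccc(/C=C2/N=C(c3ccccc3)N(C(=O)c3ccc(Cl)cc3)NC2=O)cc1` gives 300 mg/kg, compound 2 `O=C1NN(C(=O)c2ccc(Cl)cc2)C(c2ccccc2)=N/C1=C/c1ccccc1` gives 300 mg/kg, and compound 3 `Cc1ccc(C(=O)N2NC(=O)/C(=C\c3ccc(O)cc3)N=C2c2ccccc2)cc1` gives 300 mg/kg, so compound 3 stands level with compounds 1 and 2. Compound 4 `COc1ccc(/C=C2/N=C(c3ccccc3)N(C(=O)c3ccc(C)cc3)NC2=O)cc1` is not yet measured; it differs from compound 3 by methyl in place of hydrogen on an oxygen on an aromatic ring. Among the measured compounds shown here, the single measured step touching that group, no change at the digits printed from compound 1 to compound 2 (within the scatter), exchanged methoxy for hydrogen and brought no change beyond the scatter. Accordingly the estimated step of no change at the digits printed from compound 3 to compound 4 (within the scatter) is expected to show no change beyond the scatter, in neither direction. Compound 4 is therefore estimated at 300 mg/kg, within a range from 150 mg/kg to 600 mg/kg.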

Compound 4, dose for half-maximal effect: 30 mg/kg
For compound 4 the middle estimate is 10-fold (1.00 log units) above the measured one; measured number outside the range, below it.
By their numbers in this assay, from the lowest: compound 4; then compounds 1, 2 and 3 (each within the scatter of the next).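

Methyl on the oxygen on the aromatic ring is not a silent change: this assay shows a 10-fold lower number from compound 3 to compound 4 (1.00 log units; beyond the scatter). With the methoxy kept, methyl in place of chloro on an aromatic carbon also counts, giving a 10-fold lower number from compound 1 to compound 4 (1.00 log units; beyond the scatter), so the effect of the methoxy group cannot be read from the chloro pair alone. Nothing available explains either step.

From the compounds shown here alone, it remains open whether a longer chain such as ethyl on that oxygen would keep the lower number. Also open, going by these compounds, is whether an amine in place of the methyl on the other aromatic ring would do the same.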